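This account rests on a few compounds, and the source may have more. Where it says the series, first, only, none or still open, it means among the compounds named here.

Compound 1 `COc1cc(C(=O)n2ccc3ccccc32)cc(OC)c1OC`: > 10000 nM (a limit)
Compound 2 `COc1cc(C(=O)c2cccc3c2ccn3C)cc(OC)c1OC`: 26.1 nM
Compound 3 `COc1cc(C(=O)c2ccc3c(ccn3C)c2)cc(OC)c1OC`: 12.5 nM

These three compounds were tested in a functional assay (Homo sapiens) for inhibition, with a stated time of 72 h; a lower number here means a stronger inhibitor, a higher number a weaker inhibitor. Compound 1 gave only a limit of the assay, > 10000 nM. Of the two true numbers, the lower belongs to compound 3, at 12.5 nM; compound 2 stands at 26.1 nM, and the gap between the two lies beyond the usual scatter.

The next compound, compound 4 `COc1cc(C(=O)c2ccc3c(ccn3CO)c2)cc(OC)c1OC`, differs from compound 3 in one place: hydroxy in place of hydrogen on a saturated chain carbon bound to an aromatic nitrogen. This is hydroxy in place of hydrogen on a saturated chain carbon bound to an aromatic nitrogen, or methyl to hydroxymethyl. Among the measured compounds shown here, no measured pair shows this change, so the expectation starts from compound 3 at 12.5 nM and is a modest one, towards a higher number in this assay, only a little beyond the scatter. The estimated move is a 2.4-fold higher number from compound 3 to compound 4 (0.38 log units; beyond the scatter). For compound 4 the expected value is 30 nM, with an estimated range from 10 nM to 120 nM.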

Compound 4, half-maximal inhibitory concentration: 35 nM
Compound 4: the middle estimate sits 1.2-fold (0.07 log units) below what was measured; the range from low to high includes it.
By their numbers in this assay, from the lowest: compound 3; then compounds 2 and 4 (each within the scatter of the next). At a limit, above all of these: compound 1.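

Among the compounds shown here, this is the first pair in the set that differs in one place, and it shows that this position responds to a small change. In this assay, hydroxy in place of hydrogen on a saturated chain carbon bound to an aromatic nitrogen gives a weaker inhibitor (a 2.8-fold higher number from compound 3 to compound 4 (0.45 log units; beyond the scatter)), a modest step beyond the scatter, and compound 4 still reads as a true number at 35 nM rather than a limit. Nothing measured here gives a cause for this step.

The compounds shown leave open how a longer chain, an amine or a carboxylic acid on this same carbon would read in this assay. They also leave open whether the change from methyl to hydroxymethyl would move compound 2 by a similar step, as this single pair cannot establish a pattern.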